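The source may hold more compounds than are shown below. What is called first, only, known or untested is meant among the compounds shown, and "the series" means these compounds.

Compound 1, with the structure `COCc1cc(CN2CCCC2)c(O)c2ncccc12`, and compound 2, with the structure `COCc1cc(CN2CCCCC2)c(O)c2ncccc12`, share one core and differ in a single place: piperidin-1-yl in place of pyrrolidin-1-yl on a saturated chain carbon bound to an aromatic carbon. In a functional assay on MES-SA/Dx5 cells (Homo sapiens) for inhibition, with a stated time of 72 h (a lower number here means a stronger inhibitor, a higher number a weaker inhibitor), compound 1 gives 1350 nM, and compound 2 gives 912 nM, so the change produced a 1.5-fold lower number from compound 1 to compound 2 (0.17 log units; within the scatter). Compound 3, with the structure `Oc1c(C(c2cccnc2)N2CCCC2)ccc2cccnc12`, is built on a different core; the difference between the two cores is not broken down here. In this assay compound 3 gives 23400 nM, the highest number of the three, with compound 1 and compound 2 both well below it.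

Compound 4, with the structure `Oc1c(C(c2cccnc2)N2CCCCC2)ccc2cccnc12`, is not yet measured. It differs from compound 3 by piperidin-1-yl in place of pyrrolidin-1-yl on a saturated chain carbon bound to two aromatic carbons. Within the data shown here, this is the same kind of change as the one from compound 1 to compound 2, though the place differs: there the carbon is bound to an aromatic carbon, here it is bound to two aromatic carbons. Because the earlier change gave a 1.5-fold lower number from compound 1 to compound 2 (0.17 log units; within the scatter), the step from compound 3 to compound 4 is expected to be small, about a 1.5-fold lower number from compound 3 to compound 4 (0.17 log units; within the scatter). Compound 4 is therefore estimated at 16000 nM, likely between 6000 nM and 40000 nM.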

Compound 4, half-maximal inhibitory concentration: 8510 nM
The estimate for compound 4 lay 1.9-fold (0.27 log units) above the measured number; the range from low to high includes it.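

In this assay, putting piperidin-1-yl in place of pyrrolidin-1-yl on the saturated chain carbon bound to two aromatic carbons gives a 2.7-fold lower number from compound 3 to compound 4 (0.44 log units; beyond the scatter), a modest step. Set beside the earlier example, the two steps cannot be told apart, so on these two cores the change behaves about the same: the same change on two cores in this assay, a 1.5-fold lower number (0.17 log units; within the scatter) from compound 1 to compound 2 and a 2.7-fold lower number (0.44 log units; beyond the scatter) from compound 3 to compound 4, 1.9-fold (0.27 log units) apart, within the scatter of two such steps

Two pairs are a small sample, however, so this does not show that the change would behave alike on any further core in the series, and it does not explain why the numbers move as they do.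

The compounds shown leave open how another amine on this carbon, such as morpholin-4-yl or an open-chain diethylamino group, would compare with pyrrolidin-1-yl and piperidin-1-yl. They also leave open whether a larger ring still, such as azepan-1-yl, would continue the same small shift on either core.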